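A few compounds are considered here, and "the series" means these few. Any claim that something is new, unique, unknown or untested is made for them only; others in the source may bear on it.

Measured in an ADME assay on the whole organism (Rattus norvegicus) for pharmacokinetics, using cassette dosing, at a dose of 1 mg/kg by the oral route; a higher number here means that a larger share of the oral dose reaches the circulation, a lower number that a smaller share of the oral dose reaches the circulation:
- compound 1 `Cc1cc(/N=c2\[nH]c(=O)n(C[C@H](C)C(=O)O)c(=O)n2Cc2ccc(Cl)cc2)ccc1OC(C)C`: 102%
- compound 2 `CC(C)Oc1ccc(/N=c2\[nH]c(=O)n(C[C@@H](O)CO)c(=O)n2Cc2ccc(Cl)cc2)cc1Cl`: 63%

Of these two, compound 2 stands lower at 63%, and compound 1 lies above it by more than the usual scatter of repeat measurements. The next question concerns compound 3 `CC(C)Oc1ccc(/N=c2\[nH]c(=O)n(C[C@H](C)C(=O)O)c(=O)n2Cc2ccc(Cl)cc2)cc1Cl`, which has not yet been measured. It differs from compound 2 in one place, on a saturated chain carbon bound to an aromatic nitrogen: 1-carboxyethyl in place of 1,2-dihydroxyethyl on a saturated chain carbon bound to an aromatic nitrogen. Cut one bond further out, this reads as 2,3-dihydroxypropyl giving way to 2-carboxypropyl.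

Among the measured compounds shown here, no measured pair differs in one place only, so the size of this change has no direct precedent here. For the measured compounds named here, the only hint is that compound 1 already carries the 2-carboxypropyl chain and gives 102%, although compound 1 and compound 3 are not identical. On that hint, an upward move in this assay is expected, smaller than the full gap between the two measured compounds. The estimated change is a number 22 percentage points higher from compound 2 to compound 3 (beyond the scatter). With so little data the range stays wide, and for compound 3 the estimate is 85%, expected between 55% and 110%.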

Compound 3, oral bioavailability: 82.4%
For compound 3 the middle estimate is 2.6 percentage points above the measured one; the range from low to high includes it.
By their numbers in this assay, from the lowest: compound 2; then compound 3; then compound 1.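

In this assay, compound 3 puts a size on one change with the rest of the molecule held fixed: 1-carboxyethyl in place of 1,2-dihydroxyethyl, on a saturated chain carbon bound to an aromatic nitrogen, gives a number 19.4 percentage points higher from compound 2 to compound 3 (beyond the scatter). Read one bond further out, this is 2-carboxypropyl taking the place of 2,3-dihydroxypropyl, and this single pair shows that the chain alone can shift the share of the oral dose that reaches the circulation. Compound 3 also provides a second comparison in which the 2-carboxypropyl chain stays the same: chloro in place of methyl on an aromatic carbon gives a number 19.6 percentage points lower from compound 1 to compound 3 (beyond the scatter), so the chain is not the only place that moves this number, and nothing available explains either step.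

As far as these compounds go, each step rests on one pair, so it remains open whether the chain change would give a similar step in a compound carrying methyl instead of chloro on the aromatic carbon. From the compounds shown here alone, what an amine or a longer chain bearing a carboxylic acid would do at this position also remains open.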